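This account rests on a few compounds, and the source may have more. Where it says the series, first, only, none or still open, it means among the compounds named here.

Compound 1 `Cc1ccc(/C=N/NC(=O)COc2cccc3ccccc23)cc1`: 83.9 ug/mL
Compound 2 `C/C(=N\NC(=O)COc1cccc2ccccc12)c1ccc([N+](=O)[O-])cc1`: 89.3 ug/mL

In an ADME assay on MT4 cells (Homo sapiens) for cytotoxicity, read by MTT assay, with a stated time of 4 days (a lower number here means that less compound is tolerated, a higher number that more compound is tolerated), compound 1 gives 83.9 ug/mL, the lowest of the two numbers, and compound 2 gives 89.3 ug/mL, a gap that lies within the scatter. Compound 3 `O=C(COc1cccc2ccccc12)N/N=C/c1ccccc1` has not been measured. It differs from compound 1 by hydrogen in place of methyl on an aromatic carbon.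

Going by the values given here, no step between measured compounds is known, so the size of this change cannot be read from the data. Compound 3 is expected to stay close to compound 1, with a step of a 1.0-fold higher number from compound 1 to compound 3 (0.02 log units; within the scatter) that is not beyond the scatter. Compound 3 is estimated at 88 ug/mL, in the range 50 ug/mL to 150 ug/mL.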

Compound 3, half-maximal cytotoxic concentration: >= 96.6 ug/mL
Compound 3 gave a limit, no number; the forecaster's own chance of this, stated with the estimate: 15%; at least 1.0-fold (0.04 log units) between middle value and limit.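

In this assay compound 3 gives >= 96.6 ug/mL, which is a limit and not a number. Hydrogen in place of methyl on this aromatic carbon, para to a large group, now has a first reading, and it shows no loss of tolerated compound: an at least 1.1-fold higher number from compound 1 to compound 3 (0.06 log units; that floor lies within the scatter). Only a floor for this step is known, and it is set by the limit: the limit of >= 96.6 ug/mL in this assay, at which 1 of the 3 values shown sits.

As far as these compounds go, how far the step extends remains open. The compounds shown also leave open how an amine, a carboxylic acid or a longer chain at this place would read in this assay.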